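Swapping chlorines for methyls on the benzamide ring

The source may hold more compounds than are shown below. What is called first, only, known or untested is meant among the compounds shown, and "the series" means these compounds.

Three compounds share one core and differ only in the aryl group on the amide carbonyl. Compound 1 `O=C(Nc1cccc(/C=C/C(=O)c2nc3ccccc3[nH]2)c1)c1ccccc1` gives 8340 nM in a functional assay on 143B cells (Homo sapiens) for antiproliferative activity, read by MTT assay, with a stated time of 48 h; on this read-out lower numbers stand for stronger inhibition and higher numbers for weaker inhibition. Compound 2 `COc1cccc(C(=O)Nc2cccc(/C=C/C(=O)c3nc4ccccc4[nH]3)c2)c1` gives 4610 nM. Among the measured compounds shown here, compound 3 `O=C(Nc1cccc(/C=C/C(=O)c2nc3ccccc3[nH]2)c1)c1cc(Cl)cc(Cl)c1` gives 3660 nM, the lowest of the three numbers, although its gap to compound 2 is within the scatter, so only the step of a 2.3-fold lower number from compound 1 to compound 3 (0.36 log units; beyond the scatter) separates it clearly from another compound.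

Compound 4 `Cc1cc(C)cc(C(=O)Nc2cccc(/C=C/C(=O)c3nc4ccccc4[nH]3)c2)c1` is not yet measured. It carries 3,5-dimethylphenyl in place of 3,5-dichlorophenyl on a carbonyl carbon. For the measured compounds named here, two measured steps touch this part of the molecule: the step of a 2.3-fold lower number from compound 1 to compound 3 (0.36 log units; beyond the scatter) and the step of a 1.3-fold lower number from compound 2 to compound 3 (0.10 log units; within the scatter). Both show that changes on this ring have so far moved the number only a little. Going by the values given here, no measured pair exchanges chlorine for methyl, so the direction is not known. The expected step of a 1.2-fold higher number from compound 3 to compound 4 (0.09 log units; within the scatter) is therefore estimated as small, likely within the scatter. Compound 4 is expected to give about 4500 nM in this assay, in a range from 2000 nM to 10000 nM.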

Compound 4, half-maximal inhibitory concentration: 4020 nM
Beside the measured number, compound 4's estimate is 1.1-fold (0.05 log units) above it; the measured number falls inside the stated range.
By their numbers in this assay, from the lowest: compounds 3, 4, 2 and 1 (each within the scatter of the next, the first and the last beyond it).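

In this assay, replacing the 3,5-dichlorophenyl group on the carbonyl carbon with 3,5-dimethylphenyl gives a 1.1-fold higher number from compound 3 to compound 4 (0.04 log units; within the scatter), so this exchange of chlorine for methyl makes no readable difference. Among the compounds shown here, the comparison with the 3-methoxyphenyl group gives the same picture, with a 1.1-fold lower number from compound 2 to compound 4 (0.06 log units; within the scatter), while replacing plain phenyl with 3,5-dimethylphenyl gives a 2.1-fold lower number from compound 1 to compound 4 (0.32 log units; beyond the scatter), a modest step of about the same size as the one to the dichloro compound, though the 3-methoxyphenyl group goes against any wider trend, with a 1.8-fold lower number from compound 1 to compound 2 (0.26 log units; within the scatter). No evidence is available on why chlorine and methyl read alike here.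

The compounds shown leave open whether an amine or a carboxylic acid on this ring would move the number further. They also leave open whether one chlorine or one methyl would have the same effect as two.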